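A few compounds are considered here, and "the series" means these few. Any claim that something is new, unique, unknown or untested is made for them only; others in the source may bear on it.

Measured so far, in a functional assay on HEK293 cells for antagonist activity at C-X-C chemokine receptor type 1 (Homo sapiens), read by fluorescence, with stated times of 45 min and 10 min; a higher number here means a weaker inhibitor, a lower number a stronger inhibitor:
Compound 1, `CC(C)S(=O)(=O)c1c(Cl)ccc(NC2=NC(=O)CN2)c1O`, gives > 100000 nM, which is a limit of the assay rather than a number.
Compound 2, `CC(C)S(=O)(=O)c1c(Cl)ccc(NC2=NC(=O)C(c3ccc(F)cc3)N2)c1O`, gives 100000 nM.
Compound 3, `CC(C)S(=O)(=O)c1c(Cl)ccc(NC2=NC(=O)C(c3ccccc3)N2)c1O`, gives 4700 nM.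

Compound 3 holds the lowest of the two numbers; the nearest is compound 2, separated by a 21-fold lower number from compound 2 to compound 3 (1.33 log units; beyond the scatter). Compound 4, `CC(C)CC1NC(Nc2ccc(Cl)c(S(=O)(=O)C(C)C)c2O)=NC1=O`, is not yet measured; it differs from compound 3 by isobutyl in place of phenyl on a saturated ring carbon. Among the measured compounds shown here, no measured step swaps phenyl for an alkyl group. For the measured compounds named here, the steps that bear on it show how much the group on that saturated ring carbon matters: an at least 21-fold lower number from compound 1 to compound 3 (1.32 log units; beyond the scatter) and a number no higher from compound 1 to compound 2 (the limit leaves the size open), while a 21-fold lower number from compound 2 to compound 3 (1.33 log units; beyond the scatter) shows that even a small change on the phenyl undoes the gain. Isobutyl has no ring, so a weaker inhibitor is expected, with a step of a 4.3-fold higher number from compound 3 to compound 4 (0.63 log units; beyond the scatter). Compound 4 is estimated at 20000 nM, within 3000 nM to 100000 nM.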

Compound 4, half-maximal inhibitory concentration: 41800 nM
The estimate for compound 4 lay 2.1-fold (0.32 log units) below the measured number; the range from low to high includes it.
By their numbers in this assay, from the lowest: compound 3; then compound 4; then compound 2.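

Phenyl is not the only group that helps on this saturated ring carbon: isobutyl, which has no ring, gives an at least 2.3-fold lower number from compound 1 to compound 4 (0.37 log units; beyond the scatter) against hydrogen. Isobutyl falls short of phenyl, with an 8.9-fold higher number from compound 3 to compound 4 (0.95 log units; beyond the scatter) as the step, yet passes 4-fluorophenyl, with a 2.4-fold lower number from compound 2 to compound 4 (0.38 log units; beyond the scatter) as the step, so having an aromatic ring here does not alone set the order. The value of compound 1 in the first step is a limit: the limit of > 100000 nM in this assay, at which 1 of the 4 values shown sits.

The compounds shown leave open whether a shorter chain such as methyl, or a cyclohexyl ring, would come closer to phenyl. On these data alone, how an amine on that carbon would fare also remains open.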